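The compounds below may be only part of what the source reports. "The series", "measured", "known", "first", "only" and "open" are said of these compounds alone.

Measured compounds:
compound 1, `O=C(O)CC1COc2cc(OCc3ncc(-c4ccccc4)o3)ccc21`, 2.34%
compound 2, `Cc1nc(-c2cccs2)sc1COc1ccc2c(c1)OCC2CC(=O)O`, 35.2%

In a functional assay on CHO cells for agonist activity at Free fatty acid receptor 1 (Homo sapiens), read by FLIPR and calcium flux, tested at 100 nM (on this read-out higher numbers stand for a stronger effect at the one concentration tested and lower numbers for a weaker effect), compound 2 gives 35.2%, the higher of the two numbers, and compound 1 gives 2.34%, a gap beyond the scatter. Compound 3, `Cc1cccc(-c2nc(C)c(COc3ccc4c(c3)OCC4CC(=O)O)s2)c1`, has not been measured. It differs from compound 2 by 3-methylphenyl in place of thiophen-2-yl on an aromatic carbon. Among the measured compounds shown here, no measured pair shows this change, so its size can only be guessed. An upward step of a number 9.8 percentage points higher from compound 2 to compound 3 (within the scatter) is expected, of moderate size, because compound 2 already reaches 35.2%. Compound 3 is estimated at 45%, with a range from 15% to 75%.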

Compound 3, a percentage reported as activity, at one concentration (the size of the read-out at that concentration, not a potency): 47.2%
The estimate for compound 3 lay 2.2 percentage points below the measured number, and the stated range covers the measured number.
By their numbers in this assay, from the lowest: compound 1; then compound 2; then compound 3.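

In this assay, the aromatic carbon next to the ring nitrogen and next to the ring sulfur accepts a six-membered carbon ring in place of the five-membered sulfur ring, and the read-out goes a number 12 percentage points higher from compound 2 to compound 3 (beyond the scatter) with this change. Among the compounds shown here, this gives the first single-place step and shows that the ring sulfur of thiophen-2-yl is not required for this level of effect. No measurement at hand gives a reason for the step.

The compounds shown leave open what the methyl group itself contributes, as plain phenyl is not among them. As far as these compounds go, how a chloro or methoxy group on that ring would read also remains open.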